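The compounds below may be only part of what the source reports. "The series", "measured", "known", "first", "only" and "open" are said of these compounds alone.

Compound 1 `Cc1nn(-c2ncnc3nc[nH]c23)c2c1C(OC1CCCC1)CC(=O)N2` gives 62 nM
Compound 2 `Cc1nn(-c2ncnc3nc[nH]c23)c2c1C(OCCn1nccc1C)CC(=O)N2` gives 1620 nM
Compound 3 `Cc1nn(-c2ncnc3nc[nH]c23)c2c1C(OCCc1ccccc1)CC(=O)N2` gives 40 nM

All three were run in a functional assay on HEK293 cells for agonist activity at G-protein coupled receptor 39 (Homo sapiens), read by scintillation proximity assay and inositol phosphate accumulation, with a stated time of 75 min (a higher number here means that more compound is needed for the effect, a lower number that less compound is needed), and share one core, differing only in the group on the oxygen at a saturated ring carbon. Compound 1 stands second highest of the three: one step from it is within the scatter a 1.6-fold lower number from compound 1 to compound 3 (0.19 log units; within the scatter), the other is large a 26-fold higher number from compound 1 to compound 2 (1.42 log units; beyond the scatter), and the step closing that loop a 41-fold lower number from compound 2 to compound 3 (1.61 log units; beyond the scatter) is equally large. Compound 4 `Cc1nn(-c2ncnc3nc[nH]c23)c2c1C(c1ccc(F)cc1Cl)CC(=O)N2` makes a different kind of change: 2-chloro-4-fluorophenyl in place of cyclopentyloxy on a saturated ring carbon. Here the oxygen itself leaves, so no measured step tests this exactly; the steps seen only show that what sits beyond the oxygen can swing the number widely. What is expected for compound 4 is therefore a modest rise of a 2.4-fold higher number from compound 1 to compound 4 (0.38 log units; beyond the scatter), though with wide uncertainty. Compound 4 is estimated at 150 nM, expected between 20 nM and 1500 nM.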

Compound 4, half-maximal effective concentration: 280 nM
Compound 4: middle estimate off by 1.9-fold (0.27 log units), on the low side; the range from low to high includes it.
By their numbers in this assay, from the lowest: compounds 3 and 1 (each within the scatter of the next); then compound 4; then compound 2.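

Compound 4 shows that a group on this saturated ring carbon need not be attached through oxygen: a 2-chloro-4-fluorophenyl joined directly keeps activity, though at a cost (a 4.5-fold higher number from compound 1 to compound 4 (0.65 log units; beyond the scatter); a 7.0-fold higher number from compound 3 to compound 4 (0.85 log units; beyond the scatter)). It still beats the pyrazole ether (a 5.8-fold lower number from compound 2 to compound 4 (0.76 log units; beyond the scatter)). Nothing available explains why the numbers move this way.

Still open, going by these compounds, is what the chlorine and the fluorine each contribute. A plain phenyl or an aminophenyl on this carbon would help to settle that.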